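The compounds below may be only part of what the source reports. "The series", "measured", "known", "first", "only" and "open" are said of these compounds alone.

The compounds here are tested in a functional assay on MGC-803 cells (Homo sapiens) for inhibition, read by CCK-8 assay, with a stated time of 48 h; on this read-out higher numbers stand for weaker inhibition and lower numbers for stronger inhibition. Compound 1 `COc1ccc(CN(C(=O)CSC(=S)N2CCCC2)c2cc(OC)c(OC)c(OC)c2)cc1` gives > 20000 nM, which is a limit of the assay and not a number. Among the compounds with values here, compound 2 `COc1ccc(CN(C(=O)CSC(=S)N2CCCc3cc(OC)ccc32)c2cc(OC)c(OC)c(OC)c2)cc1` gives 8210 nM, the only actual number so far. Within the data shown here, the one measured step, an at least 2.4-fold lower number from compound 1 to compound 2 (0.38 log units; beyond the scatter), has 6-methoxy-1,2,3,4-tetrahydroquinolin-1-yl in place of pyrrolidin-1-yl on a thiocarbonyl carbon, and it lies beyond the scatter of repeated measurements.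

Compound 3 `COc1ccc(CN(C(=O)CSC(=S)N2CCc3ccccc3C2)c2cc(OC)c(OC)c(OC)c2)cc1` is the next to be measured. It carries 1,2,3,4-tetrahydroisoquinolin-2-yl in place of 6-methoxy-1,2,3,4-tetrahydroquinolin-1-yl on the same thiocarbonyl carbon: 1,2,3,4-tetrahydroisoquinolin-2-yl in place of 6-methoxy-1,2,3,4-tetrahydroquinolin-1-yl on a thiocarbonyl carbon. The leaving and entering groups each hold one six-membered non-aromatic ring with 1 hetero atom and one six-membered aromatic ring of carbon only. Compound 2 at 8210 nM is therefore the nearer reference, and the earlier step offers only a loose guide. In this assay, no change beyond the scatter is expected, and the estimated shift is a 1.2-fold higher number from compound 2 to compound 3 (0.09 log units; within the scatter). For compound 3 the expected value is 10000 nM, with an estimated range from 3500 nM to 25000 nM.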

Compound 3, half-maximal inhibitory concentration: 5940 nM
Beside the measured number, compound 3's estimate is 1.7-fold (0.23 log units) above it, and the stated range covers the measured number.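

In this assay, the group on the thiocarbonyl carbon can go from 6-methoxy-1,2,3,4-tetrahydroquinolin-1-yl to 1,2,3,4-tetrahydroisoquinolin-2-yl with a 1.4-fold lower number from compound 2 to compound 3 (0.14 log units; within the scatter), so this exchange, in which the methoxy group is absent from the entering group and the nitrogen is placed differently in the ring pair, makes no difference that can be told apart from repeat-to-repeat variation. A second group holding one six-membered non-aromatic ring with 1 hetero atom and one six-membered aromatic ring of carbon only also stands clear of pyrrolidin-1-yl, with an at least 3.3-fold lower number from compound 1 to compound 3 (0.52 log units; beyond the scatter), so both such groups shown now give a lower number than pyrrolidin-1-yl. Compound 1 gives a limit and not a number, so this step has only a minimum size: the limit of > 20000 nM in this assay, at which 1 of the 3 values shown sits.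

The compounds shown leave open whether the aromatic ring is what separates these groups from pyrrolidin-1-yl, a question that piperidin-1-yl or morpholin-4-yl on the same carbon would help to answer. They also leave open what a methoxy group would do on 1,2,3,4-tetrahydroisoquinolin-2-yl, or a chloro group on either ring pair.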